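The compounds below may be only part of what the source reports. "The series", "measured", "known", "first", "only" and "open" are said of these compounds alone.

Measured so far in a functional assay on MCF7 cells (Homo sapiens) for antiproliferative activity, read by MTT assay, with a stated time of 48 h; a higher number here means a weaker inhibitor, a lower number a stronger inhibitor
- compound 1 `O=C(/C=C/c1ccc(O)c(O)c1)N1CCN(c2ccccc2F)CC1` gives 1.38 ug/mL
- compound 2 `O=C(/C=C/c1ccc(O)c(O)c1)N1CCN(c2ccc(F)cc2)CC1` gives 1.44 ug/mL

For the measured compounds named here, compound 2 stands level with compound 1, the only other measured member of the series. The measured step is a 1.0-fold higher number from compound 1 to compound 2 (0.02 log units; within the scatter) and so neither compound ranks ahead of the other.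

Compound 3 `O=C(/C=C/c1ccc(O)c(O)c1)N1CCN(c2ccccc2Cl)CC1` is still unmeasured. It carries 2-chlorophenyl in place of 4-fluorophenyl on an amine nitrogen in a ring and otherwise shares the core of compound 2.

Going by the values given here, only one measured step bears on this change. Exchanging 2-fluorophenyl for 4-fluorophenyl gave a 1.0-fold higher number from compound 1 to compound 2 (0.02 log units; within the scatter) and thus showed no measurable effect of that exchange. Among the compounds with values here, that step tests fluorine alone, and no chlorine-bearing compound has been measured, so the change of halogen remains untested and the evidence is thin.

In this assay no shift beyond the scatter is expected, and no direction can be favoured. The expected step is a 1.0-fold lower number from compound 2 to compound 3 (0.01 log units; within the scatter) and it is an estimate only. For compound 3 the estimated value is 1.4 ug/mL with an expected range from 0.7 ug/mL to 3 ug/mL.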

Compound 3, half-maximal inhibitory concentration: 1.36 ug/mL
Estimate against measurement, compound 3: 1.0-fold (0.01 log units) above; measured number inside the range.
By their numbers in this assay, from the lowest: compounds 3, 1 and 2 (each within the scatter of the next).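

In this assay, compound 3 gives the series its first reading of a halogen change: chloro in place of fluoro on an aromatic carbon is a 1.0-fold lower number from compound 1 to compound 3 (0.01 log units; within the scatter). The earlier fluorine pair tested only where the halogen sits, whereas this step tests which halogen is present, and at this place on the amine nitrogen in a ring the exchange has no measurable effect. The combined change, 2-chlorophenyl in place of 4-fluorophenyl, is a 1.1-fold lower number from compound 2 to compound 3 (0.02 log units; within the scatter), so altering the halogen and its place together also leaves the number within the scatter, and no independent measurement is available to account for this flat reading.

The compounds shown leave open whether a group of another kind on that amine nitrogen, such as a methoxyphenyl, a benzyl or a simple ethyl chain, would move the number beyond the scatter. They also leave open whether a bromo or trifluoromethyl group on the phenyl would stay as flat as chloro and fluoro do here, and whether any change to the shared core would matter more than these changes.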